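Homothiocarbamate lactones: chain lengthening toward compound 4

This account rests on a few compounds, and the source may have more. Where it says the series, first, only, none or still open, it means among the compounds named here.

Compound 1: `CSC(=S)N[C@H]1CCOC1=O` gives > 128000 nM in a functional assay on MCF7 cells (Homo sapiens) for cytotoxicity, read by MTT assay, with a stated time of 72 h (on this read-out lower numbers stand for stronger inhibition and higher numbers for weaker inhibition), a limit of the assay.
Compound 2: `CCSC(=S)N[C@H]1CCOC1=O` gives > 128000 nM in this assay, again a limit.
Compound 3: `CCCCSC(=S)N[C@H]1CCOC1=O` gives > 128000 nM in this assay, also a limit.

All three measured compounds share one core and differ only in the length of the chain on the sulfur. Compound 3 stands, with the other two, at the limit of this assay; none of the three gives a number, as the limit of > 128000 nM in this assay, at which 3 of the 3 values shown sit, records. The steps among them are therefore unreadable: a step that the two limits leave unreadable from compound 1 to compound 2, a step that the two limits leave unreadable from compound 1 to compound 3 and a step that the two limits leave unreadable from compound 2 to compound 3 each lie between two limits and show neither size nor direction.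

Compound 4, `CCCCCCSC(=S)N[C@H]1CCOC1=O`, continues the same series. The change from compound 3 is ethyl in place of hydrogen on a saturated chain carbon, four bonds along the chain from a sulfur. The measured steps bear on it only in that lengthening the chain from methyl through ethyl to butyl never brought any compound below the limit; whether the next lengthening does so cannot be read from them. No step beyond the scatter is expected.

The expected step is a step that the limit leaves unreadable from compound 3 to compound 4. Compound 4 is therefore expected to give 150000 nM, within a range from 60000 nM to 400000 nM, most probably reported only as a limit.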

Compound 4, half-maximal inhibitory concentration: > 128000 nM
Compound 4 was reported as a limit (the forecaster's own chance of this, stated with the estimate: 80%); the middle value does not contradict the limit.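

Compound 4 is recorded only as a limit in this assay, as are compound 1, compound 2 and compound 3, so no step among these four compounds can be read: the limit of > 128000 nM in this assay, at which 4 of the 4 values shown sit. The compounds shown leave open whether any chain on the sulfur of the shared core would give a measurable value in this assay.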